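Acetyl ester to free hydroxyl on a purine side chain

The source may hold more compounds than are shown below. What is called first, only, known or untested is meant among the compounds shown, and "the series" means these compounds.

Working notes on a small set of substituted purines tested in a functional assay on MOLT-4 cells (Homo sapiens) for inhibition; on this read-out higher numbers stand for weaker inhibition and lower numbers for stronger inhibition.

Compound 1 `CC(=O)OC(C)n1cnc2c(Cl)nc(I)nc21` carries an acetoxy side chain on the ring nitrogen; in this assay compound 1 gives 12300 nM. Compound 2 `CC(O)n1cnc2c(Cl)nc(I)nc21` differs only by hydrogen in place of acetyl on an oxygen on a saturated carbon. For compound 2 this assay reports a limit, > 500000 nM, not a number. The step is an at least 40-fold higher number from compound 1 to compound 2 (1.60 log units; beyond the scatter); it sits at the limit of > 500000 nM in this assay, at which 2 of the 3 values shown sit.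

Compound 3 `CC(=O)OC(C)n1cnc2c(S)nc(F)nc21` has the same acetoxy side chain on a different core; the difference between the two cores is not broken down here. For compound 3 this assay reports only a limit, > 500000 nM.

Compound 4 `CC(O)n1cnc2c(S)nc(F)nc21` is to be measured. It differs from compound 3 by hydrogen in place of acetyl on an oxygen on a saturated carbon, which is the same change as that from compound 1 to compound 2. Two observations bear on the expectation. First, the measured step of the same change gave an at least large rise in the number, as shown by an at least 40-fold higher number from compound 1 to compound 2 (1.60 log units; beyond the scatter). Second, the starting point, compound 3, already sits at the limit of the assay, > 500000 nM. The step from compound 3 to compound 4 is therefore expected to read a step that the limit leaves unreadable from compound 3 to compound 4, which for an assay that stops at a limit means no measurable inhibition at all. The value expected for compound 4 is 1000000 nM, with a range from 400000 nM to 5000000 nM, and the likeliest outcome is that this assay again returns only its limit for compound 4.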

Compound 4, half-maximal inhibitory concentration: > 500000 nM
Compound 4 was reported as a limit; the forecaster's own chance of this, stated with the estimate: 95%; the middle value does not contradict the limit.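

Compound 3 and compound 4 both stand only at a limit of this assay, so the change from acetoxy to hydroxy gives no readable step between them, and both sit at the shared limit: the limit of > 500000 nM in this assay, at which 3 of the 4 values shown sit.

The compounds shown leave open whether this change alters inhibition at all on the core of compound 3, where neither compound gives a number.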